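Ortho substitution on the isoxazole-linked aryl ring

The source may hold more compounds than are shown below. What is called first, only, known or untested is meant among the compounds shown, and "the series" means these compounds.

Of the compounds shown here, three carry numbers so far. Compound 1 `CCN(CC)c1ccc(NC(=O)c2c(-c3ccccc3-c3ccccc3)noc2C)cc1` gives 1300 nM in an assay on isolated protein for binding affinity to growth hormone secretagogue receptor type 1 (Homo sapiens); on this read-out lower numbers stand for stronger inhibition and higher numbers for weaker inhibition. Compound 2 `CCN(CC)c1ccc(NC(=O)c2c(-c3c(Cl)cccc3Cl)noc2C)c(C(F)(F)F)c1` gives 4100 nM in this assay, and compound 3 `CCN(CC)c1ccc(NC(=O)c2c(-c3c(Cl)cccc3Cl)noc2CCC2OCCCO2)c(C)c1` gives 9 nM. Compound 1 thus holds the second highest of the three numbers: its nearest neighbour is compound 2, whose number is higher by a margin beyond the scatter, while compound 3 sits far lower, also well beyond the scatter. Compound 2 and compound 3 differ from compound 1 in several places at once, so neither gives a clean single-change step.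

The next compound, compound 4 `CCN(CC)c1ccc(NC(=O)c2c(-c3ccccc3Cl)noc2C)cc1`, is reached from compound 1 by one change: chloro in place of phenyl on an aromatic carbon. For the measured compounds named here, no measured pair in the set isolates this change. Compound 2 and compound 3 both carry a dichlorinated ring at this position, but their other differences prevent a direct reading. The expectation for this assay is a small step downward in the number from compound 1 to compound 4, a 1.6-fold lower number from compound 1 to compound 4 (0.21 log units; within the scatter), likely within the scatter of repeated measurements. Compound 4 is therefore estimated at 800 nM, with a range from 200 nM to 3000 nM.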

Compound 4, half-maximal inhibitory concentration: 690 nM
Beside the measured number, compound 4's estimate is 1.2-fold (0.06 log units) above it; low and high end bracket the measured number.
By their numbers in this assay, from the lowest: compound 3; then compounds 4 and 1 (each within the scatter of the next); then compound 2.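

In this assay, for the compounds shown here, the first clean single-change step is a 1.9-fold lower number from compound 1 to compound 4 (0.28 log units; within the scatter): chloro in place of phenyl on an aromatic carbon, ortho to a large group. A single chlorine atom thus stands in for a six-carbon aromatic ring at this position with no change beyond the scatter, so the read-out does not depend on keeping the phenyl ring there, at least on the core of compound 1. No measured property of these groups is available to account for this result.

The compounds shown leave open how a methoxy group, an amine, a carboxylic acid or a bare hydrogen would read at this position, and so whether any group there moves the number beyond the scatter. They also leave open whether chloro in place of phenyl would give a similar step on the core of compound 3, which carries a longer chain ending in a six-membered acetal ring and a second chloro on the aryl ring, so the present step cannot yet be carried over to that compound.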